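Compound 1 to compound 4: acetyl leaves the oxygen

The compounds below may be only part of what the source reports. "The series", "measured", "known", "first", "only" and "open" are said of these compounds alone.

In an ADME assay on ECV-304 cells (Homo sapiens) for cytotoxicity, read by MTT assay, with a stated time of 72 h (a lower number here means a stronger inhibitor, a higher number a weaker inhibitor), compound 1 (`COc1cc(C2=C(c3cc(C)c(OC)c(C)c3)C(OC(C)=O)CC2=O)cc(OC)c1OC`) gives > 100 ug/mL, which is a limit of the assay and not a number. Compound 1 therefore stands at the limit of > 100 ug/mL in this assay, at which 1 of the 3 values shown sits. Within the data shown here, compound 2 (`COc1ccc(C2=C(c3cc(OC)c(OC)c(OC)c3)C(=O)C(O)C2)cc1Cl`) gives 20 ug/mL, the only single number so far. For compound 3 (`COc1ccc(C2=C(c3cc(OC)c(OC)c(OC)c3)C(=O)CC2OC(C)=O)cc1NC=O`) the entry reads "not determined" (no result reported).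

Compound 4 (`COc1cc(C2=C(c3cc(C)c(OC)c(C)c3)C(O[SiH2]C(C)(C)C)CC2=O)cc(OC)c1OC`) keeps the core of compound 1. The acetyl leaves, and a silicon-containing group with no common name enters, on an oxygen on a saturated carbon: a group of 5 heavy atoms (4 carbon, 1 silicon; no ring) in place of a group of 3 heavy atoms (2 carbon, 1 oxygen; no ring), on an oxygen on a saturated carbon.

Among the measured compounds shown here, no measured pair differs in one place, so no step size can be carried over to this change. For the measured compounds named here, compound 2, at 20 ug/mL, shows only that a compound of this set can return a number in this assay. The estimated change is an at least 1.4-fold lower number from compound 1 to compound 4 (0.15 log units; that floor lies within the scatter), a modest shift towards stronger inhibition, and another reading that reports only a limit remains quite possible. For compound 4, the expected value is 70 ug/mL, with an estimated range from 15 ug/mL to 200 ug/mL.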

Compound 4, half-maximal inhibitory concentration: 15 ug/mL
Compound 4: the middle estimate sits 4.7-fold (0.67 log units) above what was measured; the measured number falls inside the stated range.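

In this assay, among these compounds, the change on this oxygen on a saturated carbon gives the first readable step: an at least 6.6-fold lower number from compound 1 to compound 4 (0.82 log units; beyond the scatter). That step gives a floor and not a full size, since compound 1 stands at a limit of the assay and not at a number: the limit of > 100 ug/mL in this assay, at which 1 of the 4 values shown sits. On the core of compound 1, then, the acetyl is not required for a numerical reading, and the silicon-containing group of 5 heavy atoms brings the reading within the measurable range.

The compounds shown leave open whether the silicon or the size of the group accounts for this step; a free hydroxyl or a carbon-only ether such as a tert-butyl ether on this oxygen would separate the two. As far as these compounds go, whether the same change acts alike on any core other than that of compound 1 also remains open.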